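The source may report more compounds than this note shows. Statements on the series, on what has been measured and on what is new or still open speak of the compounds shown alone.

Measured so far:
- compound 1 `COc1ccc(Nc2nc(-c3cccc(F)c3)nc3ccc(F)cc23)cc1`: 42300 nM
- compound 2 `Oc1ccccc1Nc1nc(-c2cccc(F)c2)nc2ccc(F)cc12`: > 50000 nM, a limit and not a number

Both readings come from a functional assay on HT29-AK cells (Homo sapiens) for cytotoxicity, read by MTT assay, with a stated time of 48 h; a higher number here means a weaker inhibitor, a lower number a stronger inhibitor. Compound 2 has no number in this assay, only the limit > 50000 nM.

Compound 3 `Cc1ccc(Nc2nc(-c3cccc(F)c3)nc3ccc(F)cc23)cc1` is next, and it differs from compound 2 by 4-methylphenyl in place of 2-hydroxyphenyl on a nitrogen on an aromatic ring.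

Within the data shown here, one measured step bears on this place, namely an at least 1.1-fold higher number from compound 1 to compound 2 (0.07 log units; that floor lies within the scatter), with 2-hydroxyphenyl in place of 4-methoxyphenyl. Going by these compounds, only a floor is known for that step, so its true size stays open. The expectation therefore leans on compound 1, at 42300 nM, which carries 4-methoxyphenyl where compound 3 carries 4-methylphenyl.

No large step is expected in this assay, and any movement should be toward a lower number. The expected step is an at least 1.4-fold lower number from compound 2 to compound 3 (0.15 log units; that floor lies within the scatter). The reading may also stop at the limit of this assay. For compound 3 the estimate is 35000 nM, with an expected range of 12000 nM to 50000 nM.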

Compound 3, half-maximal inhibitory concentration: > 50000 nM
Compound 3 was reported as a limit; the forecaster's own chance of this, stated with the estimate: 35%; middle value at least 1.4-fold (0.15 log units) from the limit.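

In this assay, methyl in place of methoxy on an aromatic carbon gives an at least 1.1-fold higher number from compound 1 to compound 3 (0.07 log units; that floor lies within the scatter), so only a floor is known for this change and that floor does not separate it from the scatter. The step between compound 2 and compound 3 cannot be read, as both carry only a limit; what the new reading adds is that 4-methylphenyl, with no hydrogen-bond donor or acceptor, ends in the same reported state as 2-hydroxyphenyl, which has one of each. At this position on the nitrogen, only compound 1 now carries a number, and the readings gather at one limit: the limit of > 50000 nM in this assay, at which 2 of the 3 values shown sit.

The true values of compound 2 and compound 3 stay open, so the shown compounds give no size for either change. Also open, going by these compounds, is the reading with a group such as 4-aminophenyl or 4-carboxyphenyl on the same nitrogen, and whether any group there gives a clearly lower number on the shared core.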